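Swapping a hydroxypropyl chain for chlorine on the shared core

The compounds below may be only part of what the source reports. "The series", "measured", "known", "first", "only" and "open" are said of these compounds alone.

The compounds here share one core, seen in compound 1, `Cc1cccc(Nc2nc(-c3ccncc3CCCO)cs2)c1`, and differ only in the group on one aromatic carbon of a six-membered aromatic ring with 1 nitrogen. Each is tested in a functional assay on RCC4 cells (Homo sapiens) for inhibition, read by XTT assay, with a stated time of 4 days; a higher number here means a weaker inhibitor, a lower number a stronger inhibitor. Compound 1 gives 6920 nM. Compound 2, `Cc1cccc(Nc2nc(-c3ccnc(-c4cc[nH]n4)c3)cs2)c1`, carries a pyrazolyl group and gives 480 nM; 490 nM (2 entries), so it is the stronger inhibitor of the two (the several entries of compound 2 in this assay, 480 nM; 490 nM (2 entries)). Compound 3, `Cc1cccc(Nc2nc(-c3ccncc3-c3ccc(C(N)=O)cc3)cs2)c1`, carries a carboxamide-bearing phenyl and gives 4100 nM; 4170 nM (2 entries), which lies within the usual scatter of the value for compound 1 (the several entries of compound 3 in this assay, 4100 nM; 4170 nM (2 entries)). Compound 1 thus sits at the weak end of what has been measured, without being separable from compound 3.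

Compound 4, `Cc1cccc(Nc2nc(-c3ccncc3Cl)cs2)c1`, has not yet been measured. It differs from compound 1 in one place: chloro in place of 3-hydroxypropyl on an aromatic carbon. The 3-hydroxypropyl group that leaves is the largest of the three changes known so far to give a weak inhibitor, and the chloro group that enters is small and lacks any hydrogen-bond donor or acceptor. Nothing measured here shows what a small, uncharged group does at this position, so the expected step from compound 1 to compound 4 is a 2.0-fold lower number from compound 1 to compound 4 (0.30 log units; within the scatter), a modest gain that may not exceed the scatter. Compound 4 is therefore estimated at 3500 nM, expected to fall between 900 nM and 12000 nM in this assay.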

Compound 4, half-maximal inhibitory concentration: 2950 nM
Beside the measured number, compound 4's estimate is 1.2-fold (0.07 log units) above it; low and high end bracket the measured number.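

Putting chloro in place of 3-hydroxypropyl on an aromatic carbon gives a 2.3-fold lower number from compound 1 to compound 4 (0.37 log units; beyond the scatter) in this assay. Among the compounds shown here, this is the first single change at this position that can be read as a step, and it shows that the activity of compound 1 does not depend on the chain or on its hydrogen-bond donor and acceptor, since a single chlorine atom with neither does modestly better. The change alters size and hydrogen-bond count together, and no measurement shown here bears on why the number falls.

On these data alone, what remains open is which part of the change matters, the loss of the hydroxyl group or the loss of chain length, and a plain propyl chain at this place would help separate the two. It is also unclear how far the number can move at this position, since compound 4 remains a modest gain over compound 1, and groups such as methyl, methoxy or an amine, set on the same aromatic carbon of the shared core, would show whether a small group other than chloro gives a similar result.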